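A few compounds are considered here, and "the series" means these few. Any claim that something is new, unique, unknown or untested is made for them only; others in the source may bear on it.

In an assay on isolated protein for binding affinity to cysteinyl leukotriene receptor 1 (Cavia porcellus), tested at 10 uM (on this read-out higher numbers stand for more inhibition at the one concentration tested (going by the name of the read-out) and lower numbers for less inhibition), compound 2 `c1ccc(COc2cccc(OCCCc3nnn[nH]3)c2)cc1` gives 12%. Compound 1 `c1cc(OCCCc2nnn[nH]2)cc(OCc2cnc3ccccc3c2)c1` gives 15% in this assay, and the gap between the two lies within the usual scatter, so neither can be set above the other. Compound 3 `c1ccc(COc2cccc(OCCCc3nnn[nH]3)c2)nc1` has not yet been measured; it differs from compound 2 by pyridin-2-yl in place of phenyl on a saturated chain carbon bound to an oxygen on an aromatic ring. The two measured compounds say nothing about this change, so no step beyond the scatter is expected in this assay. The estimated step of no change at the digits printed from compound 2 to compound 3 (within the scatter) is accordingly small. Compound 3 is expected to give about 12%, between 0% and 30%.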

Compound 3, a percentage reported as inhibition, at one concentration (the size of the read-out at that concentration, not a potency): 10%
The estimate for compound 3 lay 2 percentage points above the measured number; the range from low to high includes it.
By their numbers in this assay, from the lowest: compounds 3, 2 and 1 (each within the scatter of the next).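

In this assay, pyridin-2-yl in place of phenyl on a saturated chain carbon bound to an oxygen on an aromatic ring gives a number 2 percentage points lower from compound 2 to compound 3 (within the scatter), so at this position a ring nitrogen in place of a ring carbon, adding one hydrogen-bond acceptor, brings no step beyond the scatter. The earlier compounds shown here held no step of any kind at this place. No evidence is at hand that bears on this result.

Going by these compounds, whether an amine or a carboxylic acid on this ring, or a longer chain at this place, would bring a step beyond the scatter stays open.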